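This account rests on a few compounds, and the source may have more. Where it says the series, first, only, none or still open, it means among the compounds named here.

Measured in an ADME assay on Caco-2 cells (Homo sapiens) for permeability, in the apical to basolateral direction, at pH 7.4; on this read-out lower numbers stand for lower permeability and higher numbers for higher permeability:
- compound 1 `Cc1ccc2[nH]c(C(=O)N[C@H]3CN(S(=O)(=O)c4ccccc4)C[C@@H]3C(=O)N[C@@H]3CCCN(C)C3)cc2c1`: 0.76 10^-6 cm/s
- compound 2 `Cc1oc(-c2ccc(C(F)(F)F)cc2)nc1C(=O)N[C@H]1CN(S(=O)(=O)c2ccccc2)C[C@@H]1C(=O)N[C@H]1CCCNC1`: 0.1 10^-6 cm/s
- compound 3 `O=C(N[C@H]1CN(S(=O)(=O)c2ccccc2)C[C@@H]1C(=O)N1C[C@H]2CCNC[C@H]21)c1cc(-c2ccccc2Cl)on1`: 0.53 10^-6 cm/s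

In this assay, compound 3 gives 0.53 10^-6 cm/s. Compound 1 gives 0.76 10^-6 cm/s, and compound 2 gives 0.1 10^-6 cm/s. The gap between compound 3 and compound 1 lies within the usual scatter. The gap between compound 3 and compound 2 lies outside the usual scatter, and compound 2 has the lower number.

Compound 4 `CN(C(=O)[C@H]1CN(S(=O)(=O)c2ccccc2)C[C@@H]1NC(=O)c1cc(-c2ccccc2Cl)on1)[C@H]1CCCNC1` keeps the rest of compound 3 and changes one place, on a carbonyl carbon: a group of 8 heavy atoms (6 carbon, 2 nitrogen; one six-membered non-aromatic ring with 1 hetero atom) in place of a group of 8 heavy atoms (6 carbon, 2 nitrogen; one four-membered non-aromatic ring with 1 hetero atom, one six-membered non-aromatic ring with 1 hetero atom), on a carbonyl carbon. The four-membered non-aromatic ring is gone, while the six-membered non-aromatic ring remains.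

For the measured compounds named here, no two measured compounds differ in only one place, so the data offer no direct guide to the size of this change. The leaving and entering groups match in their counts of heavy atoms, donors and acceptors, so the value of compound 3, 0.53 10^-6 cm/s, is the natural starting point. The expected step of a 1.3-fold lower number from compound 3 to compound 4 (0.12 log units; within the scatter) is small and should stay within the scatter. For compound 4 the estimate is 0.4 10^-6 cm/s, with an expected range of 0.15 10^-6 cm/s to 1.1 10^-6 cm/s.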

Compound 4, apparent permeability: 0.11 10^-6 cm/s
The estimate for compound 4 lay 3.6-fold (0.56 log units) above the measured number; measured number below the stated range.
By their numbers in this assay, from the lowest: compounds 2 and 4 (each within the scatter of the next); then compounds 3 and 1 (each within the scatter of the next).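

For the compounds shown here, this is the first step that can be read at a single place, and the place is not a silent one: in this assay, losing the four-membered non-aromatic ring on a carbonyl carbon, while the six-membered non-aromatic ring remains, comes with a 4.8-fold lower number from compound 3 to compound 4 (0.68 log units; beyond the scatter). The leaving and entering groups match in heavy atoms, hydrogen-bond donors and hydrogen-bond acceptors, so at this position those counts alone do not fix the number. Nothing measured here accounts for the drop.

A single pair cannot separate the loss of the four-membered ring from the other differences between the two groups, such as their defined stereocentres. An open-chain amine or a carboxylic acid on the same carbonyl carbon would show how far the number can move at this position.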